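A few compounds are considered here, and "the series" means these few. Any claim that something is new, unique, unknown or untested is made for them only; others in the source may bear on it.

Of the compounds shown here, three sharing one core have been tested for their ability to hold back the growth of a human prostate cancer cell line, and they differ only in the aromatic group attached to a nitrogen on that core. Compound 1, `C=CC(=O)Nc1cccc(NC(=O)CSc2nc(Nc3cccc(OC)c3)c3ccccc3n2)c1`, gives 34900 nM in a functional assay on PC-3 cells (Homo sapiens) for inhibition, read by MTT assay, with a stated time of 72 h; a lower number here means a stronger inhibitor, a higher number a weaker inhibitor. Compound 2, `C=CC(=O)Nc1cccc(NC(=O)CSc2nc(Nc3ccc(C(F)(F)F)cc3)c3ccccc3n2)c1`, gives 12500 nM in this assay. Compound 3, `C=CC(=O)Nc1cccc(NC(=O)CSc2nc(Nc3ccc(Cl)c(Cl)c3)c3ccccc3n2)c1`, gives 27600 nM in this assay. Among these three numbers, compound 3 stands second highest: the step of a 1.3-fold lower number from compound 1 to compound 3 (0.10 log units; within the scatter) is a small one, whereas the step of a 2.2-fold higher number from compound 2 to compound 3 (0.34 log units; beyond the scatter) is a real difference. Compound 4, `C=CC(=O)Nc1cccc(NC(=O)CSc2nc(Nc3ccc(F)c(Cl)c3)c3ccccc3n2)c1`, differs from compound 3 by a single swap: fluoro in place of chloro on an aromatic carbon. For the measured compounds named here, no measured pair shows exactly this exchange of one halogen for another on the same aromatic carbon; the steps seen so far, a 2.8-fold lower number from compound 1 to compound 2 (0.45 log units; beyond the scatter) and a 2.2-fold higher number from compound 2 to compound 3 (0.34 log units; beyond the scatter), involve wholesale changes of the aromatic group and are at most modest. Going by the values given here, a change as small as the one leading to compound 4 is therefore expected to stay within the scatter, meaning a step of about a 1.1-fold lower number from compound 3 to compound 4 (0.04 log units; within the scatter). The estimate for compound 4 is 25000 nM, with a range from 10000 nM to 60000 nM.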

Compound 4, half-maximal inhibitory concentration: > 50000 nM
Compound 4: a limit, no number (the forecaster's own chance of this, stated with the estimate: 5%); middle value at least 2.0-fold (0.30 log units) from the limit.
By their numbers in this assay, from the lowest: compound 2; then compounds 3 and 1 (each within the scatter of the next). At a limit, above all of these: compound 4.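

For compound 4 the assay gives a limit and not a number: the limit of > 50000 nM in this assay, at which 1 of the 4 values shown sits. For the compounds shown here, this is the first change of a single atom, fluoro in place of chloro para to a large group, and it gives an at least 1.8-fold higher number from compound 3 to compound 4 (0.25 log units; that floor lies within the scatter), while the wholesale change of aromatic group gives an at least 1.4-fold higher number from compound 1 to compound 4 (0.15 log units; that floor lies within the scatter), so neither floor yet sets compound 4 clearly apart. Only an at least 4.0-fold higher number from compound 2 to compound 4 (0.60 log units; beyond the scatter) clearly exceeds the scatter, showing that this single-atom swap did not bring the number down and that the 3-chloro-4-fluorophenyl group falls clearly behind 4-(trifluoromethyl)phenyl.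

From the compounds shown here alone, how far compound 4 lies beyond its limit remains open, and with it whether the swap from chloro to fluoro has a real effect. Also open, going by these compounds, is what a bromo group or an amine on this same aromatic carbon would give.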